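The source may report more compounds than this note shows. Statements on the series, on what has been measured and on what is new or still open speak of the compounds shown alone.

The measured compounds in an assay on JAR cells for inhibition of sodium- and chloride-dependent glycine transporter 1 (Homo sapiens), read by scintillation proximity assay (a higher number here means a weaker inhibitor, a lower number a stronger inhibitor), are these:

compound 1 `CCCS(=O)(=O)N1CCN(C2(CNC(=O)c3ccccc3C(F)(F)F)CCCCC2)CC1` — compound 1 gives 48.5 nM
compound 2 `CCCS(=O)(=O)N1CCN(C2(CNC(=O)c3cccc(C(F)(F)F)c3Cl)CCCCC2)CC1` — compound 2 gives 77.9 nM
compound 3 `CCCS(=O)(=O)N1CCN(C2(CNC(=O)c3c(Cl)cccc3Cl)CCCCC2)CC1` — compound 3 gives 12.8 nM

Compound 3 holds the lowest of the three numbers. The step of a 3.8-fold lower number from compound 1 to compound 3 (0.58 log units; beyond the scatter) and the step of a 6.1-fold lower number from compound 2 to compound 3 (0.78 log units; beyond the scatter) both lie beyond the scatter, whereas the step of a 1.6-fold higher number from compound 1 to compound 2 (0.21 log units; within the scatter) does not. Compound 4 `CCCS(=O)(=O)N1CCN(C2(CNC(=O)c3c(OC)cc(F)cc3SC)CCCCC2)CC1` differs from compound 3 in one place: 4-fluoro-2-methoxy-6-(methylsulfanyl)phenyl in place of 2,6-dichlorophenyl on a carbonyl carbon. Among the compounds with values here, no measured pair makes this particular exchange. The three steps that bear on it all swap one substituted phenyl for another on the same carbonyl carbon, and each of them moves the number by a modest amount at most, never by a large one, with the exchange between compound 1 and compound 2 staying inside the scatter. On that basis compound 4 is expected to remain within a modest distance of compound 3, most likely with a somewhat higher number, the expected step being a 2.0-fold higher number from compound 3 to compound 4 (0.29 log units; within the scatter). The estimate for compound 4 in this assay is 25 nM, with a range from 8 nM to 80 nM.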

Compound 4, half-maximal inhibitory concentration: 6.1 nM
Estimate against measurement, compound 4: 4.1-fold (0.61 log units) above, and the stated range ends above it.
By their numbers in this assay, from the lowest: compound 4; then compound 3; then compounds 1 and 2 (each within the scatter of the next).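

In this assay, putting 4-fluoro-2-methoxy-6-(methylsulfanyl)phenyl in place of 2,6-dichlorophenyl on the carbonyl carbon gives a 2.1-fold lower number from compound 3 to compound 4 (0.32 log units; beyond the scatter), so the lowest number in this set no longer belongs to a chlorine-bearing phenyl but to a group of 11 heavy atoms in place of 8, with oxygen, fluorine and sulfur and with hydrogen-bond acceptors that 2,6-dichlorophenyl lacks. Within the data shown here, the range of numbers across this one place also widens, with the first large step of the set, a 13-fold lower number from compound 2 to compound 4 (1.11 log units; beyond the scatter), alongside a modest one, an 8.0-fold lower number from compound 1 to compound 4 (0.90 log units; beyond the scatter), while the rest of the molecule stays the same. No measurement here says which part of the entering group accounts for the change.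

The methoxy, fluoro and methylsulfanyl groups arrive together, so the compounds shown cannot separate their contributions. Going by these compounds, how a 2,6-dimethoxyphenyl, or a 2-methoxy-6-(methylsulfanyl)phenyl without the fluorine, would read at this place remains open, as does the effect of an amine or a carboxylic acid on that phenyl.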